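Swapping Bromo for Trifluoromethyl on a Shared Core

A few compounds are considered here, and "the series" means these few. Any claim that something is new, unique, unknown or untested is made for them only; others in the source may bear on it.

Compound 1, `Oc1ccc(CNc2cc(C(F)(F)F)cc3[nH]ncc23)cc1`: in an assay for inhibition of Indoleamine 2,3-dioxygenase 1 (Homo sapiens), with stated times of 10 min and 60 min, tested at 100 uM (a higher number here means a stronger effect of the compound at the concentration tested, a lower number a weaker effect), compound 1 gives 81%.
Compound 2, `O=C1NCc2c(NCc3ccccc3[N+](=O)[O-])cccc21`: in this assay compound 2 gives 9%.
Compound 3, `O=[N+]([O-])c1cccc(CNc2cc(Br)cc3[nH]ncc23)c1`: in this assay compound 3 gives 95%.

Among the three measured compounds, compound 3 stands highest in this assay. Its nearest neighbour is compound 1, whose number is lower by more than the usual scatter, while compound 2 lies far below both of them.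

Compound 4, `O=[N+]([O-])c1cccc(CNc2cc(C(F)(F)F)cc3[nH]ncc23)c1`, is the next compound to be measured. It differs from compound 3 in one place: trifluoromethyl in place of bromo on an aromatic carbon. Among the measured compounds shown here, no pair of measured compounds differs in only one place, so the size of this change cannot be read directly from the numbers at hand. What can be said is that compound 1 already carries a trifluoromethyl group on the shared core and reaches 81%, a high number in its own right.

On that basis the step is expected to be small, with no clear direction beyond the scatter, as a number 7 percentage points lower from compound 3 to compound 4 (within the scatter). Compound 4 is therefore estimated to give about 88%, within a range from 70% to 98%.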

Compound 4, a percentage reported as inhibition, at one concentration (the size of the read-out at that concentration, not a potency): 69%
For compound 4 the middle estimate is 19 percentage points above the measured one; the measured number lies below the stated range.
By their numbers in this assay, from the lowest: compound 2; then compound 4; then compound 1; then compound 3.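

At this position on the shared core, the two groups are not interchangeable: in this assay, trifluoromethyl in place of bromo gives a number 26 percentage points lower from compound 3 to compound 4 (beyond the scatter). Among the compounds shown here, this is the first pair that differs in one place only, so it gives the first direct reading of what a single change does here, with the rest of compound 3 held fixed. The group that enters has four heavy atoms against one for the group that leaves, while neither carries a hydrogen-bond donor, a hydrogen-bond acceptor or a net charge, and nothing measured here bears on why the number falls.

One pair cannot show whether the number tracks the size of the group on this aromatic carbon, and a chloro group, a methyl group or a nitrile at the same place would help to test that. As far as these compounds go, it also stays open whether the swap has a similar effect with other groups elsewhere on the molecule, and a bromo partner of compound 1 would give a second reading of the same change.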